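Cyclohexyl to 4-Fluorophenyl on a Diamide Core

The source may hold more compounds than are shown below. What is called first, only, known or untested is meant among the compounds shown, and "the series" means these compounds.

compound 1 `O=C(N[C@H]1CCC[C@H](NC(=O)C2CCCCC2)C1)c1cccc(Cl)c1`: 857 nM
compound 2 `N#Cc1cccc(C(=O)N[C@@H]2CCC[C@H](NC(=O)c3ccccn3)C2)c1`: > 10000 nM
compound 3 `N#Cc1cccc(C(=O)N[C@H]2CCC[C@H](NC(=O)c3ccccn3)C2)c1`: > 10000 nM

Among the compounds with values here, in a functional assay on HEK293 cells for antagonist activity at metabotropic glutamate receptor 5 (Homo sapiens), read by FLIPR and calcium flux (a higher number here means a weaker inhibitor, a lower number a stronger inhibitor), compound 1 gives 857 nM, the only number among the three. Compound 2 gives only a limit in this assay. Compound 3 likewise gives only a limit. The step that the two limits leave unreadable from compound 2 to compound 3 cannot be read, as the limit of > 10000 nM in this assay, at which 2 of the 3 values shown sit, and the fact that compounds 2 and 3 differ only in the configuration as drawn show. Compound 4 `O=C(N[C@H]1CCC[C@H](NC(=O)c2cccc(Cl)c2)C1)c1ccc(F)cc1` differs from compound 1 by 4-fluorophenyl in place of cyclohexyl on a carbonyl carbon. Within the data shown here, no measured step touches this change, so the expectation rests on compound 1 alone. The step from compound 1 to compound 4 is estimated as a 1.2-fold higher number from compound 1 to compound 4 (0.07 log units; within the scatter), with no clear direction beyond the scatter. Compound 4 is therefore expected at about 1000 nM, with a range from 200 nM to 6000 nM.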

Compound 4, half-maximal inhibitory concentration: 194 nM
Compound 4: middle estimate off by 5.2-fold (0.71 log units), on the high side, and the stated range ends above it.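

In this assay, the group on this carbonyl carbon matters: 4-fluorophenyl in place of cyclohexyl gives a 4.4-fold lower number from compound 1 to compound 4 (0.65 log units; beyond the scatter) and shows that an aromatic ring is accepted here without loss. This is the first readable step among the compounds shown, and it is a gain. Nothing measured here bears on the cause of this step. On these data alone, whether the step belongs to the aromatic ring or to its fluorine remains open, a question that a plain phenyl group here would separate. As far as these compounds go, how an amine or a longer chain on this carbonyl carbon would read also remains unknown.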